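Removing a silicon-bearing chain from three inactive compounds

A few compounds are considered here, and "the series" means these few. Any claim that something is new, unique, unknown or untested is made for them only; others in the source may bear on it.

Compound 1 `COCn1c(CC(O)(CO)CO)cc(=O)[nH]c1=O`, compound 2 `C[Si](C)(C)CCOCn1c(CC(O)(CO)CO)cc(=O)[nH]c1=O` and compound 3 `Cc1c(CC(O)COCc2ccccc2)n(COCC[Si](C)(C)C)c(=O)[nH]c1=O` were all tested in a functional assay on MIA PaCa-2 cells (Homo sapiens) for antiproliferative activity, read by MTT assay, with a stated time of 72 h; on this read-out lower numbers stand for stronger inhibition and higher numbers for weaker inhibition. In this assay compound 1 gives > 100000 nM, which is a limit of the assay and not a number. Compound 2 gives > 100000 nM, also a limit. Compound 3 gives > 100000 nM, again a limit. The change a hydrogen atom in place of a group of 5 heavy atoms (4 carbon, 1 silicon; no ring), on a saturated chain carbon bound to an oxygen on a saturated carbon therefore yields a step that the two limits leave unreadable from compound 2 to compound 1, as both values share (the limit of > 100000 nM in this assay, at which 3 of the 3 values shown sit). The difference between the cores of compound 2 and compound 3 is not broken down here. Compound 4 `COCn1c(CC(O)COCc2ccccc2)c(C)c(=O)[nH]c1=O` arises from compound 3 by the same change, (a hydrogen atom in place of a group of 5 heavy atoms (4 carbon, 1 silicon; no ring), on a saturated chain carbon bound to an oxygen on a saturated carbon). Because compound 3 sits at the limit of > 100000 nM in this assay, at which 3 of the 3 values shown sit, compound 4 is expected to show a step that the limit leaves unreadable from compound 3 to compound 4. The estimated value for compound 4 is 150000 nM, spanning 50000 nM to 500000 nM.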

Compound 4, half-maximal inhibitory concentration: > 100000 nM
Compound 4 was reported as a limit (the forecaster's own chance of this, stated with the estimate: 85%); the middle value does not contradict the limit.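

No step can be read from compound 3 to compound 4, because both stop at a limit of the assay: (the limit of > 100000 nM in this assay, at which 4 of the 4 values shown sit). The compounds shown leave open whether this change affects activity at all, and what would give a readable value.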